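Methyl to Ethoxy: Expected Effect on Cell Growth Inhibition

The source may hold more compounds than are shown below. What is called first, only, known or untested is meant among the compounds shown, and "the series" means these compounds.

Compound 1 `COc1ccccc1-c1ncnn1-c1cc(OC)c(OC)c(OC)c1` and compound 2 `COc1cc(-n2ncnc2-c2ccc(C)cc2)cc(OC)c1OC` share one core and differ only in one aromatic ring. In a functional assay on A549 cells (Homo sapiens) for antiproliferative activity, read by MTT assay, with a stated time of 72 h (a lower number here means a stronger inhibitor, a higher number a weaker inhibitor), compound 1 gives > 10000 nM, which is a limit of the assay rather than a number (the limit of > 10000 nM in this assay, at which 1 of the 2 values shown sits). In this assay, for the measured compounds named here, compound 2 gives 1100 nM, the only true number so far. The step of an at least 9.0-fold lower number from compound 1 to compound 2 (0.95 log units; beyond the scatter) shows that this ring matters. Compound 3 `CCOc1ccc(-c2ncnn2-c2cc(OC)c(OC)c(OC)c2)cc1` changes compound 2 by ethoxy in place of methyl on an aromatic carbon. Going by the values given here, no measured step involves an ethoxy, so little guides the forecast. A step of a 1.4-fold lower number from compound 2 to compound 3 (0.14 log units; within the scatter) within the usual scatter is expected. Compound 3 is therefore estimated at 800 nM, in the range 250 nM to 3000 nM.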

Compound 3, half-maximal inhibitory concentration: 100 nM
Compound 3: the middle estimate sits 8.0-fold (0.90 log units) above what was measured, outside the stated range (below it).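

The step of an 11-fold lower number from compound 2 to compound 3 (1.04 log units; beyond the scatter) in this assay shows that a small change at this one place, para to a large group, can move the number strongly. The earlier compounds shown here showed only that replacing the whole aromatic ring matters; this pair shows that ethoxy in place of methyl alone is enough. Nothing shown here explains why the step is so large.

Whether the oxygen or the longer chain accounts for the step stays open, and methoxy or ethyl at this place would separate the two. As far as these compounds go, how a propoxy chain or an amine would behave here also remains unknown.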